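The compounds below may be only part of what the source reports. "The series", "measured", "known", "first", "only" and "open" are said of these compounds alone.

Three compounds have been measured in an assay on isolated protein for inhibition of serine/threonine-protein kinase TNNI3K (Homo sapiens); a higher number here means a weaker inhibitor, a lower number a stronger inhibitor:

compound 1 `CNc1cc(Oc2ccc(NC(=O)Nc3cccc(C(F)(F)F)c3)cc2)ncn1`: 40 nM
compound 2 `CNc1nccc(Oc2ccc(NC(=O)Nc3cccc(C(F)(F)F)c3)cc2)n1`: 50 nM
compound 3 `Cc1cc(Oc2ccc(NC(=O)Nc3cccc(C(F)(F)F)c3)cc2)ncn1`: 160 nM

All three share the same core and differ only in the small group on one aromatic carbon of the pyrimidine ring. Compound 3 carries the highest number of the three: its nearest neighbour is compound 2, with a 3.2-fold higher number from compound 2 to compound 3 (0.51 log units; beyond the scatter), and its most distant is compound 1, with a 4.0-fold higher number from compound 1 to compound 3 (0.60 log units; beyond the scatter). Compounds 1 and 2 sit within the scatter of each other, so nothing separates them.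

Compound 4 `O=C(Nc1ccc(Oc2cc(NCCO)ncn2)cc1)Nc1cccc(C(F)(F)F)c1` has not yet been measured. It differs from compound 3 by (2-hydroxyethyl)amino in place of methyl on an aromatic carbon. For the measured compounds named here, the one measured step that bears directly on this change is the one from compound 1 to compound 3, where methyl in place of methylamino raised the number, a 4.0-fold higher number from compound 1 to compound 3 (0.60 log units; beyond the scatter). Compound 4 reverses that direction, putting a nitrogen-bearing group with two hydrogen-bond donors back onto the same carbon, now with a longer chain. The step from compound 2 to compound 3 points the same way. A modest drop in the number, beyond the scatter, is therefore expected: a 3.2-fold lower number from compound 3 to compound 4 (0.51 log units; beyond the scatter). Compound 4 is estimated at 50 nM, within 20 nM to 130 nM in this assay.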

Compound 4, half-maximal inhibitory concentration: 32 nM
For compound 4 the middle estimate is 1.6-fold (0.19 log units) above the measured one; the measured number falls inside the stated range.
By their numbers in this assay, from the lowest: compounds 4, 1 and 2 (each within the scatter of the next); then compound 3.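

In this assay, the result shows that the nitrogen-linked group on this aromatic carbon can be much larger than methylamino without any cost, and that (2-hydroxyethyl)amino in place of methyl gives a clear gain (a 5.0-fold lower number from compound 3 to compound 4 (0.70 log units; beyond the scatter)). Adding hydroxymethyl to the chain carbon bound to the nitrogen leaves no readable difference (a 1.3-fold lower number from compound 1 to compound 4 (0.10 log units; within the scatter)), and the comparison with the other methylamino compound also stays within the scatter (a 1.6-fold lower number from compound 2 to compound 4 (0.19 log units; within the scatter)). So the end of the chain can carry a hydroxyl group with no measurable penalty, although nothing shown here explains why the groups on this carbon differ as they do.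

The compounds shown cannot tell whether the hydroxyl group contributes anything itself, since a 2-methoxyethylamino group, a plain ethylamino group or a longer 3-hydroxypropylamino chain on the same carbon would be needed to separate the oxygen from the chain length. From the compounds shown here alone, it also remains open whether a terminal amine, as in a 2-aminoethylamino group, would fit here, and how much further this chain can grow before the number rises.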